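Liver Cell Tolerance from Compound 1 to Compound 4

A few compounds are considered here, and "the series" means these few. Any claim that something is new, unique, unknown or untested is made for them only; others in the source may bear on it.

Of the compounds shown here, three have so far been tested in an ADME assay on Huh-7 cells (Homo sapiens) for cytotoxicity; a higher number here means that more compound is tolerated, a lower number that less compound is tolerated. Compound 1, `Cc1ccccc1CNc1nn(-c2ccc(F)cc2F)cc1CNCCN1CCN(C)CC1`, gives > 20000 nM, which is a limit of the assay rather than a measured number. Compound 2, `Cc1c(CNCCN2CCN(C)CC2)c(-c2ccccc2)nn1-c1ccc(F)cc1`, likewise gives only the limit > 20000 nM. Compound 3, `Cc1ccccc1-c1nn(-c2ccc(F)cc2F)cc1CN1CCN(c2ccccc2)CC1`, also gives only the limit > 20000 nM. Compound 1 therefore stands exactly where the other two measured compounds stand, at the limit of > 20000 nM in this assay, at which 3 of the 3 values shown sit, and no order among the three can be read from these limits.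

Compound 4, `CN1CCN(CCNCc2cn(-c3ccc(F)cc3F)nc2-c2cccc(N(C)C)c2)CC1`, is built from the same atoms as compound 1, joined differently. The change is 3-(dimethylamino)phenyl in place of (2-methylbenzyl)amino on an aromatic carbon. Going by the values given here, no step between two measured compounds is available to show how such a change moves this read-out; the only guide is that all three measured compounds sit at the limit. A step of no size beyond the usual scatter is expected, and it is thought likely that the assay again reports only a limit. Compound 4 is expected to give about 20000 nM in this assay, with a range from 8000 nM to 50000 nM. The expected step is a number no higher from compound 1 to compound 4 (the limit leaves the size open), which lies within the scatter.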

Compound 4, half-maximal cytotoxic concentration: > 20000 nM
Compound 4: only a limit was reported; the forecaster's own chance of this, stated with the estimate: 75%; the middle value lies on the limit itself.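

In this assay compound 4 gives > 20000 nM as a limit of the assay and not a number. Going by these compounds alone, compound 1 also has only a limit, so no step between compound 1 and compound 4 can be read. The compounds shown leave open the concentration at which any of them would reach the half-maximal cytotoxic effect.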